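The source may hold more compounds than are shown below. What is called first, only, known or untested is meant among the compounds shown, and "the series" means these compounds.

In a functional assay on the whole organism with Mus musculus as the target (on this read-out lower numbers stand for an effect already at smaller amounts and higher numbers for an effect only at larger amounts of compound), compound 2 `CCCC[C@](C)(OC)[C@H](O)/C=C/C1[C@H](O)CC(=O)[C@@H]1C/C=C\CCCC(=O)OC` gives 0.479 mg/kg and compound 1 `CCCC[C@](C)(OC)[C@@H](O)/C=C/C1[C@H](O)CC(=O)[C@@H]1C/C=C\CCCC(=O)OC` gives 0.912 mg/kg as its value, so the two lie within the scatter of each other. Compound 3 `CCCC[C@@](C)(OC)[C@H](O)/C=C/C1[C@H](O)CC(=O)[C@@H]1C/C=C\CCCC(=O)OC` keeps the atoms and bonds of compound 2 and alters one stereocentre (the two compounds have the same atoms and bonds; at least one stereo element is drawn with a configuration in one of them and without one in the other: 1 of 7 stereo elements differ; a stereocentre at a saturated chain carbon is drawn S in compound 2 and R in compound 3) at a saturated chain carbon. For the measured compounds named here, the only measured step that bears on this is a 1.9-fold lower number from compound 1 to compound 2 (0.28 log units; within the scatter) at another stereocentre of that kind, so no shift beyond the scatter is expected in this assay in either direction. The estimated step is a 1.3-fold higher number from compound 2 to compound 3 (0.10 log units; within the scatter) in size. For compound 3 the estimate is 0.6 mg/kg with an expected range from 0.2 mg/kg to 1.8 mg/kg on this read-out.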

Compound 3, dose for half-maximal effect: 0.757 mg/kg
For compound 3 the middle estimate is 1.3-fold (0.10 log units) below the measured one, and the stated range covers the measured number.
By their numbers in this assay, from the lowest: compounds 2, 3 and 1 (each within the scatter of the next).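

In this assay, this second stereocentre at a saturated chain carbon also leaves the number within the scatter, with a 1.6-fold higher number from compound 2 to compound 3 (0.20 log units; within the scatter) as its step. Changing both stereocentres together stays within the scatter too, with a 1.2-fold lower number from compound 1 to compound 3 (0.08 log units; within the scatter) as the step, so neither a single change nor the double change separates these compounds. Nothing available gives a cause for this result.

All three compounds share the same atoms and bonds. On these data alone, how the number responds to a new group, such as an amine or a carboxylic acid, stays open.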